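Piperidine Sulfonamide in Place of a Cyclohexylmethyl Sulfonyl

The compounds below may be only part of what the source reports. "The series", "measured", "known", "first", "only" and "open" are said of these compounds alone.

Three measured compounds share one core and differ only in the group on an amine nitrogen in a ring. Compound 1 `CC(=O)N1CCN(c2ccc(OCC3CCN(C(=O)OC(C)C)CC3)cn2)CC1` carries an acetyl there. In a functional assay on CHO-K1 cells for agonist activity at Glucose-dependent insulinotropic receptor (Homo sapiens), read by a luciferase reporter, with a stated time of 5 h (a higher number here means that more compound is needed for the effect, a lower number that less compound is needed), compound 1 reaches only the assay limit > 10000 nM, a limit rather than a number, as noted in the limit of > 10000 nM in this assay, at which 1 of the 3 values shown sits. Compound 2 `CCCS(=O)(=O)N1CCN(c2ccc(OCC3CCN(C(=O)OC(C)C)CC3)cn2)CC1` carries a propylsulfonyl, and in this assay compound 2 gives 300 nM. Compound 3 `CC(C)OC(=O)N1CCC(COc2ccc(N3CCN(S(=O)(=O)CC4CCCCC4)CC3)nc2)CC1` carries a (cyclohexylmethyl)sulfonyl, and in this assay compound 3 gives 90 nM. The steps of an at least 33-fold lower number from compound 1 to compound 2 (1.52 log units; beyond the scatter) and an at least 110-fold lower number from compound 1 to compound 3 (2.04 log units; beyond the scatter) are both large, while a 3.3-fold lower number from compound 2 to compound 3 (0.52 log units; beyond the scatter) is modest. Of the two numbers shown, compound 3 has the lowest, with compound 2 the nearest.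

Compound 4 `CC(C)OC(=O)N1CCC(COc2ccc(N3CCN(S(=O)(=O)N4CCCCC4)CC3)nc2)CC1` has not yet been measured. Its difference from compound 3 is piperidin-1-yl in place of cyclohexylmethyl on a sulfonyl sulfur. For the measured compounds named here, the only measured step touching the group on the sulfonyl sulfur is a 3.3-fold lower number from compound 2 to compound 3 (0.52 log units; beyond the scatter), a modest one, and here both the leaving and the entering group are six-membered non-aromatic rings, so no step beyond the scatter is expected. Compound 4 is expected to give 120 nM in this assay, with a range from 40 nM to 400 nM. That corresponds to an expected step of a 1.3-fold higher number from compound 3 to compound 4 (0.12 log units; within the scatter), within the scatter.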

Compound 4, half-maximal effective concentration: 1000 nM
The estimate for compound 4 lay 8.3-fold (0.92 log units) below the measured number; the measured number lies above the stated range.
By their numbers in this assay, from the lowest: compound 3; then compound 2; then compound 4. At a limit, above all of these: compound 1.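

The change of cyclohexylmethyl to piperidin-1-yl on a sulfonyl sulfur gives an 11-fold higher number from compound 3 to compound 4 (1.05 log units; beyond the scatter) in this assay, so at this position a shared ring size does not settle the number: both groups hold a six-membered non-aromatic ring. Nor does a ring on the sulfonyl sulfur always beat a plain chain: piperidin-1-yl in place of propyl gives a 3.3-fold higher number from compound 2 to compound 4 (0.52 log units; beyond the scatter), while cyclohexylmethyl in place of that same chain went the other way, with a 3.3-fold lower number from compound 2 to compound 3 (0.52 log units; beyond the scatter), so compound 4 and compound 3 stand on opposite sides of compound 2. Replacing acetyl with (piperidin-1-yl)sulfonyl still leaves an at least 10-fold lower number from compound 1 to compound 4 (1.00 log units; beyond the scatter), a step that starts from a limit and not a number: the limit of > 10000 nM in this assay, at which 1 of the 4 values shown sits.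

The change swaps a ring carbon for a nitrogen and also sets the ring directly on the sulfur, and these compounds cannot separate those two differences; a cyclohexyl group directly on the sulfonyl sulfur would pull them apart. On these data alone, whether a morpholin-4-yl or a dimethylamino group on the same sulfur would follow piperidin-1-yl also stays open.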